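Swapping the amide aryl group on a weak antiproliferative scaffold

The source may hold more compounds than are shown below. What is called first, only, known or untested is meant among the compounds shown, and "the series" means these compounds.

Measured compounds:
Compound 1, `NC(=O)c1c(NC(=O)c2ccccc2Cl)sc2c1CCN(C(=O)Nc1ccccc1Cl)C2`: 16300 nM
Compound 2, `NC(=O)c1c(NC(=O)c2ccccc2Cl)sc2c1CCN(C(=S)Nc1cccnc1)C2`: 38600 nM

Both compounds were tested in a functional assay on MKN-74 cells (Homo sapiens) for antiproliferative activity, with a stated time of 24 h; a lower number here means a stronger inhibitor, a higher number a weaker inhibitor. Compound 1 and compound 2 share a core and differ only at the ring amine nitrogen, where the step of a 2.4-fold higher number from compound 1 to compound 2 (0.37 log units; beyond the scatter) was seen. On the two numbers available, compound 2 stands at the weaker end, its nearest neighbour being compound 1.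

Compound 3, `NC(=O)c1c(NC(=O)c2ccc[nH]2)sc2c1CCN(C(=S)Nc1cccnc1)C2`, has not yet been measured. It keeps the thiourea side of compound 2 unchanged and differs from it only at the amide: 1H-pyrrol-2-yl in place of 2-chlorophenyl on a carbonyl carbon. For the measured compounds named here, no measured step touches this carbonyl position; the single step on record, from compound 1 to compound 2, sits on the other side of the core and so gives no direct guide to the size or direction of this change. With nothing to lean on, the most defensible expectation is a number near that of compound 2, with a wide band on either side.

For compound 3 the expected step is a 1.0-fold higher number from compound 2 to compound 3 (0.02 log units; within the scatter), and its estimated value in this assay is 40000 nM, within a range of 12000 nM to 130000 nM.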

Compound 3, half-maximal inhibitory concentration: > 50000 nM
Compound 3 was reported as a limit; the forecaster's own chance of this, stated with the estimate: 15%; at least 1.2-fold (0.09 log units) between middle value and limit.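

Compound 3 gives > 50000 nM in this assay, and this is a limit of the assay, not a measured number: the limit of > 50000 nM in this assay, at which 1 of the 3 values shown sits.

For the compounds shown here, this is the first view of the amide side of the shared core, where 1H-pyrrol-2-yl in place of 2-chlorophenyl on a carbonyl carbon gives an at least 1.2-fold higher number from compound 2 to compound 3 (0.11 log units; that floor lies within the scatter). The five-membered aromatic ring with its hydrogen-bond donor therefore brings no gain over the 2-chlorophenyl ring, but the size of any loss cannot be read, and even the floor of the step does not separate the two compounds beyond the scatter.

From the compounds shown here alone, what remains open is whether any group on this carbonyl carbon can bring the number down, for instance a plain phenyl ring, a thiophene ring or a short chain ending in an amine. Going by these compounds alone, also unsettled is whether the same swap would behave alike when the ring amine nitrogen carries the group found in compound 1 rather than the one in compound 2.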